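Nitro in place of trifluoromethyl: a step within scatter

A few compounds are considered here, and "the series" means these few. Any claim that something is new, unique, unknown or untested is made for them only; others in the source may bear on it.

Three close analogues share one core. Compound 1 `Cc1cccc(NC(=O)CSC(=S)N[C@H]2CCOC2=O)c1` gives in a functional assay on EC9706 cells (Homo sapiens) for cytotoxicity, read by MTT assay, with a stated time of 72 h (on this read-out higher numbers stand for weaker inhibition and lower numbers for stronger inhibition), only a limit, > 128000 nM. Compound 2 `O=C(CSC(=S)N[C@H]1CCOC1=O)Nc1cccc(Cl)c1` gives 107000 nM in this assay, and compound 3 `O=C(CSC(=S)N[C@H]1CCOC1=O)Nc1cccc(C(F)(F)F)c1` gives 79700 nM. Compound 3 thus holds the lower of the two numbers, but the step of a 1.3-fold lower number from compound 2 to compound 3 (0.13 log units; within the scatter) lies within the scatter, as do the floors of an at least 1.1-fold lower number from compound 1 to compound 2 (0.07 log units; that floor lies within the scatter) and an at least 1.6-fold lower number from compound 1 to compound 3 (0.20 log units; that floor lies within the scatter). Compound 4 `O=C(CSC(=S)N[C@H]1CCOC1=O)Nc1cccc([N+](=O)[O-])c1` differs from compound 3 by nitro in place of trifluoromethyl on an aromatic carbon. All three measured changes at that aromatic carbon stayed within the scatter, so the step of a 1.1-fold lower number from compound 3 to compound 4 (0.03 log units; within the scatter) is expected to stay within it as well. Compound 4 is therefore estimated at 75000 nM in this assay, between 35000 nM and 150000 nM.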

Compound 4, half-maximal inhibitory concentration: > 128000 nM
Compound 4: only a limit was reported (the forecaster's own chance of this, stated with the estimate: 20%); at least 1.7-fold (0.23 log units) between middle value and limit.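

Nitro on this aromatic carbon gives only a limit, the same reading as methyl in compound 1: the limit of > 128000 nM in this assay, at which 2 of the 4 values shown sit. Against the two groups with numbers, trifluoromethyl to nitro gives an at least 1.6-fold higher number from compound 3 to compound 4 (0.20 log units; that floor lies within the scatter) and chloro to nitro gives an at least 1.1-fold higher number from compound 2 to compound 4 (0.07 log units; that floor lies within the scatter). Both are floors within the scatter, so they do not set nitro apart from either group, and the step between the two limits cannot be read.

Going by these compounds, whether nitro truly differs from trifluoromethyl or chloro here stays open. So does what an amine or a carboxylic acid on this carbon would give.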